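The source may report more compounds than this note shows. Statements on the series, on what has been measured and on what is new or still open speak of the compounds shown alone.

Compound 1 `COc1ccc(-c2cn3cc(C4=CCN(S(=O)(=O)C5CCCC5)CC4)ccc3n2)cc1OC` gives 103000 nM in an ADME assay on HEK293 cells (Homo sapiens) for cytotoxicity, read by MTT assay, with a stated time of 48 h; a lower number here means a stronger inhibitor, a higher number a weaker inhibitor.
Compound 2 `COc1ccc(-c2cn3cc(C4=CCN(S(=O)(=O)CCc5ccccc5)CC4)ccc3n2)cc1OC` gives 70300 nM in this assay.
Compound 3 `COc1ccc(-c2cn3cc(C4=CCN(C(=O)C5CC5)CC4)ccc3n2)cc1OC` gives 77600 nM in this assay.

Compound 1 holds the highest of the three numbers, yet the gap to compound 3 a 1.3-fold lower number from compound 1 to compound 3 (0.12 log units; within the scatter) and the gap to compound 2 a 1.5-fold lower number from compound 1 to compound 2 (0.17 log units; within the scatter) both sit within the scatter, so the three measured compounds cannot be told apart in this assay.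

Compound 4 `COc1ccc(-c2cn3cc(C4=CCN(C(=O)C(C)(C)C)CC4)ccc3n2)cc1OC` has not yet been measured. It differs from compound 1 as follows: (tert-butyl)carbonyl in place of cyclopentylsulfonyl on an amine nitrogen in a ring. Among the compounds with values here, the step that bears most directly on this change is the one from compound 1 to compound 3 a 1.3-fold lower number from compound 1 to compound 3 (0.12 log units; within the scatter), where a different carbonyl group also replaced the cyclopentylsulfonyl on the same ring nitrogen, and the step from compound 1 to compound 2 a 1.5-fold lower number from compound 1 to compound 2 (0.17 log units; within the scatter) shows that altering the group on the sulfonyl sulfur likewise stayed within the scatter. On this basis no step beyond the scatter is expected for compound 4 in this assay, and the expected step of a 1.2-fold lower number from compound 1 to compound 4 (0.08 log units; within the scatter) is small. Compound 4 is accordingly estimated at 85000 nM, within a range from 40000 nM to 180000 nM.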

Compound 4, half-maximal inhibitory concentration: 66600 nM
Compound 4: middle estimate off by 1.3-fold (0.11 log units), on the high side; measured number inside the range.
By their numbers in this assay, from the lowest: compounds 4, 2, 3 and 1 (each within the scatter of the next).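

With the tert-butyl amide, a carbonyl group without a ring now sits on this ring nitrogen in this assay, and the step from the cyclopentylsulfonyl group, a 1.5-fold lower number from compound 1 to compound 4 (0.19 log units; within the scatter), stays within the scatter, as does the step from the phenethylsulfonyl group, a 1.1-fold lower number from compound 2 to compound 4 (0.02 log units; within the scatter). The change on the carbonyl carbon itself, tert-butyl in place of cyclopropyl, is new and gives a 1.2-fold lower number from compound 3 to compound 4 (0.07 log units; within the scatter), so this swap of the carbonyl substituent does not separate the two amides in this assay. No measurement is available that would explain these numbers.

All four compounds carry a carbonyl or sulfonyl group on this ring nitrogen, which leaves open whether a simple alkyl group or the unsubstituted amine there would give a step beyond the scatter. Also open, on these data alone, is whether a change elsewhere on the shared core, such as a hydroxyl group in place of a methoxy group, would do so.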